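Swapping the pendant aryl ring: nitrile out, trifluoromethyl in

The source may hold more compounds than are shown below. What is called first, only, known or untested is meant among the compounds shown, and "the series" means these compounds.

Measured compounds:
Compound 1 `CC/C(=C(/c1ccc(/C=C/C(=O)O)cc1)c1cc2ccccc2[nH]1)c1cccc(C)c1` gives 140 nM in a functional assay on MCF7 cells (Homo sapiens) for inhibition; a lower number here means a stronger inhibitor, a higher number a weaker inhibitor.
Compound 2 `CC/C(=C(/c1ccc(/C=C/C(=O)O)cc1)c1cc2ccccc2[nH]1)c1ccc(Cl)cc1C#N` gives 14 nM in this assay.

Compound 2 has the lowest of the two numbers in this assay; the step of a 10-fold lower number from compound 1 to compound 2 (1.00 log units; beyond the scatter) separates it from compound 1. Compound 3 `CC/C(=C(/c1ccc(/C=C/C(=O)O)cc1)c1cc2ccccc2[nH]1)c1ccc(Cl)c(C(F)(F)F)c1` has not yet been measured. It differs from compound 2 by one change: 4-chloro-3-(trifluoromethyl)phenyl in place of 4-chloro-2-cyanophenyl on a double-bonded chain carbon bound to a double-bonded chain carbon and a saturated chain carbon. Among the compounds with values here, the only step that bears on this position is the one from compound 1 to compound 2, and it was modest. Within the data shown here, no measured pair shows what happens when the nitrile is removed and a trifluoromethyl is added on this ring, so the expectation rests on that single step and carries wide uncertainty. Compound 3 is therefore expected to remain somewhat weaker than compound 2 in this assay, a step of a 2.9-fold higher number from compound 2 to compound 3 (0.46 log units; beyond the scatter). The estimate for compound 3 is 40 nM, with a range of 10 nM to 160 nM.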

Compound 3, half-maximal inhibitory concentration: 2200 nM
For compound 3 the middle estimate is 55-fold (1.74 log units) below the measured one, and the stated range ends below it.
By their numbers in this assay, from the lowest: compound 2; then compound 1; then compound 3.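

In this assay, the replacement of 4-chloro-2-cyanophenyl by 4-chloro-3-(trifluoromethyl)phenyl produces a 160-fold higher number from compound 2 to compound 3 (2.20 log units; beyond the scatter) and shows that the 4-chloro group present on both rings does not by itself preserve the strength of compound 2. The same ring also gives a 16-fold higher number from compound 1 to compound 3 (1.20 log units; beyond the scatter) when it replaces 3-methylphenyl, so this position can yield a weaker inhibitor than the 3-methylphenyl compound as well as a stronger one. The data shown offer no measured explanation for this loss.

The compounds shown do not separate the effect of losing the nitrile from that of gaining the trifluoromethyl, as the two rings differ in both respects. Going by these compounds, it also remains open how this ring position would respond to a methoxy group or an amine in place of either group.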